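A few compounds are considered here, and "the series" means these few. Any claim that something is new, unique, unknown or untested is made for them only; others in the source may bear on it.

Measured so far in an assay on HEK293 cells for inhibition of Lysophosphatidylserine lipase ABHD12 (Homo sapiens), read by scintillation counting, with stated times of 30 min and 5 min; on this read-out lower numbers stand for stronger inhibition and higher numbers for weaker inhibition:
compound 1 `Cc1ccc(C(=O)NC2CCCCCC2)c(=O)n1Cc1ccc(F)cc1`: > 10000 nM, a limit of the assay.
compound 2 `Cc1c(-c2ccc(F)cc2)cc(C(=O)NC2CCCCCC2)c(=O)n1Cc1ccc(F)cc1`: 600 nM.

Compound 2 holds the only number shown; the other entry is a limit (the limit of > 10000 nM in this assay, at which 1 of the 2 values shown sits). For the measured compounds named here, the single step between them, an at least 16-fold lower number from compound 1 to compound 2 (1.22 log units; beyond the scatter), is large and beyond the scatter, so the ring that enters there carries most of what the series shows.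

Compound 3 `Cc1c(Br)cc(C(=O)NC2CCCCCC2)c(=O)n1Cc1ccc(F)cc1` differs from compound 2 by bromo in place of 4-fluorophenyl on an aromatic carbon. Going by the values given here, the only measured step bearing on this change is an at least 16-fold lower number from compound 1 to compound 2 (1.22 log units; beyond the scatter), which concerns the same position. With the 4-fluorophenyl ring leaving, a good part of that gain is expected to be lost, though bromo is not hydrogen and may keep some of it. A step of an 8.3-fold higher number from compound 2 to compound 3 (0.92 log units; beyond the scatter) toward weaker inhibition is therefore expected in this assay. For compound 3 the estimate is 5000 nM, with a range of 1500 nM to 20000 nM, and a real chance that only a limit is reported.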

Compound 3, half-maximal inhibitory concentration: > 10000 nM
Compound 3 gave a limit, no number; the forecaster's own chance of this, stated with the estimate: 40%; at least 2.0-fold (0.30 log units) between middle value and limit.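

In this assay, bromo in place of 4-fluorophenyl gives an at least 16-fold higher number from compound 2 to compound 3 (1.22 log units; beyond the scatter), which shows that the inhibition measured for compound 2 is not retained by just any substituent on this aromatic carbon, as a single bromine atom does not stand in for the 4-fluorophenyl ring. Compound 3 gives > 10000 nM, a limit of the assay and not a number. Bromo and hydrogen on this carbon cannot be told apart, since the step between compound 1 and compound 3 cannot be read: the limit of > 10000 nM in this assay, at which 2 of the 3 values shown sit.

Still open, from the compounds shown here alone, is whether the fluorine of the ring matters, which an unsubstituted phenyl would address. Also open, going by these compounds, is how a pyridyl, a benzyl or a cyclohexyl group at this carbon would compare with the 4-fluorophenyl of compound 2.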